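From 4-fluorophenyl to cyclohexyl on a sulfur side chain

The source may report more compounds than this note shows. Statements on the series, on what has been measured and on what is new or still open speak of the compounds shown alone.

In a functional assay on PC-9 cells (Homo sapiens) for inhibition, read by MTT assay, with a stated time of 72 h (on this read-out higher numbers stand for weaker inhibition and lower numbers for stronger inhibition), compound 1 `Cc1cc(Nc2cc(-c3ccccc3)[nH]n2)n2nc(SCc3ccc(F)cc3)nc2n1` gives 8110 nM as its value. Compound 2 `Cc1cc(Nc2cc(-c3cccs3)[nH]n2)n2nc(SCc3ccc(Br)cc3)nc2n1` gives 4890 nM in this assay as well, and these two numbers lie within the usual scatter of each other, so neither can be ranked over the other. Compound 3 `Cc1cc(Nc2ccn(Cc3ccccc3)n2)n2nc(SCc3ccc(Br)cc3)nc2n1` gives > 50000 nM and this is a limit of the assay rather than a number.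

Compound 4 `Cc1cc(Nc2cc(-c3ccccc3)[nH]n2)n2nc(SCC3CCCCC3)nc2n1` differs from compound 1 in one place, with cyclohexyl in place of 4-fluorophenyl on a saturated chain carbon bound to a sulfur as the count of what changes: cyclohexyl in place of 4-fluorophenyl on a saturated chain carbon bound to a sulfur. Going by the values given here, no measured pair of compounds shows this change on its own, so any expectation is loose. A small move toward weaker inhibition, no larger than the scatter, is expected, with a 1.5-fold higher number from compound 1 to compound 4 (0.17 log units; within the scatter) as the estimated step. In this assay the estimated value for compound 4 is 12000 nM with an expected range from 4000 nM to 40000 nM around it.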

Compound 4, half-maximal inhibitory concentration: > 50000 nM
Compound 4: only a limit was reported; the forecaster's own chance of this, stated with the estimate: 15%; at least 4.1-fold (0.61 log units) between middle value and limit.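

In this assay, going by these compounds alone, exchanging the 4-fluorophenyl on a saturated chain carbon bound to a sulfur for cyclohexyl gives an at least 6.1-fold higher number from compound 1 to compound 4 (0.78 log units; beyond the scatter), the first change in a single place that can be read. With the rest of compound 1 unchanged, an aromatic ring at this position therefore cannot be swapped for a non-aromatic ring of carbon only without inhibition weakening. The value for compound 4 is a limit and not a number: the limit of > 50000 nM in this assay, at which 2 of the 4 values shown sit.

Whether the loss of the aromatic ring or the loss of the fluorine accounts for the step stays open, and a plain benzyl on the sulfur would separate the two. From the compounds shown here alone, how a longer chain carrying the same 4-fluorophenyl, or an amine on that chain, would read also remains unknown.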